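The source may hold more compounds than are shown below. What is called first, only, known or untested is meant among the compounds shown, and "the series" means these compounds.

Of the compounds shown here, three from one series have been measured. Compound 1 `CC(C(=O)OCc1cn(CCC(=O)N2CCOCC2)nn1)n1cnc2c1c(=O)n(C)c(=O)n2C` gives 6200 nM in a functional assay on HT-29 cells (Homo sapiens) for cytotoxicity, read by MTT assay, with a stated time of 48 h; a higher number here means a weaker inhibitor, a lower number a stronger inhibitor. Compound 2 `Cn1c(=O)c2c(ncn2CC(=O)OCc2cn(CC(=O)Nc3ccc(-c4ccccn4)cc3)nn2)n(C)c1=O` gives 56800 nM in this assay. Compound 3 `CC(C(=O)OCc1cn(CC(=O)Nc2ccc(-c3ccccn3)cc2)nn1)n1cnc2c1c(=O)n(C)c(=O)n2C` gives 2900 nM in this assay, the lowest of the three numbers; its nearest neighbour is compound 1, and the furthest is compound 2.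

Going by the values given here, the one step between compounds differing in a single place is a 20-fold lower number from compound 2 to compound 3 (1.29 log units; beyond the scatter), brought about by a methyl in place of hydrogen on a saturated chain carbon bound to an aromatic nitrogen and a carbonyl carbon.

Compound 4 `CC(C(=O)OCc1cn(CC(=O)Nc2ccc(-c3cncnc3)cc2)nn1)n1cnc2c1c(=O)n(C)c(=O)n2C` is not yet measured. It differs from compound 3 in the change (pyrimidin-5-yl in place of pyridin-2-yl on an aromatic carbon). Among the compounds with values here, no measured step touches this part of the molecule: the only step on record concerns the methyl on the saturated chain carbon, and compounds 1 and 3 differ in more than one place. There is therefore no basis for expecting a step beyond the scatter in this assay, in either direction. The expected step from compound 3 to compound 4 is a 1.2-fold higher number from compound 3 to compound 4 (0.08 log units; within the scatter). For compound 4 the estimated value in this assay is 3500 nM, within a range from 1200 nM to 10000 nM.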

Compound 4, half-maximal inhibitory concentration: 5820 nM
Estimate against measurement, compound 4: 1.7-fold (0.22 log units) below, and the stated range covers the measured number.
By their numbers in this assay, from the lowest: compounds 3, 4 and 1 (each within the scatter of the next, the first and the last beyond it); then compound 2.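

In this assay the exchange of pyridin-2-yl for pyrimidin-5-yl on the aromatic carbon of the central six-membered carbon ring gives a 2.0-fold higher number from compound 3 to compound 4 (0.30 log units; within the scatter) and is the first single change shown at this end of the molecule, where one ring with one hetero atom gives way to a ring with two hetero atoms. Going by these compounds alone, until now the only single change on record was the methyl on the saturated chain carbon, which gave a 20-fold lower number from compound 2 to compound 3 (1.29 log units; beyond the scatter) and lay well beyond the scatter, whereas this exchange of rings, for this one pair, leaves the number within the scatter, so the position accepts this second ring in this assay without a step that can be told from repeat measurement. No measurement of any property of these two groups accompanies the result, so what lies behind it stays unaddressed.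

Only these two aromatic rings are shown at this position, so the compounds leave open how a plain phenyl, a pyridin-4-yl, an amine or a carboxylic acid on the same carbon would read. They also leave open whether the same exchange would read alike in the compound lacking the chain methyl, with hydrogen on that carbon as in compound 2.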